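Replacing the dibromohydroxyphenyl of compound 3 with dichlorophenyl

The source may hold more compounds than are shown below. What is called first, only, known or untested is meant among the compounds shown, and "the series" means these compounds.

Three compounds sharing one core were measured in a functional assay on HT-29 cells (Homo sapiens) for cytotoxicity, read by MTT assay, with a stated time of 72 h; on this read-out higher numbers stand for weaker inhibition and lower numbers for stronger inhibition. Compound 1 `CN(C)CCn1cnnc1-c1cc(Oc2ccc(NC(=O)N/N=C/c3ccc(F)cc3Cl)cc2F)ccn1` gives 510 nM. Compound 2 `CN(C)CCn1cnnc1-c1cc(Oc2ccc(NC(=O)N/N=C/c3cccc(Cl)c3Cl)cc2F)ccn1` gives 130 nM, and the move a 3.9-fold lower number from compound 1 to compound 2 (0.59 log units; beyond the scatter). Compound 3 `CN(C)CCn1cnnc1-c1cc(Oc2ccc(NC(=O)N/N=C/c3cc(Br)c(O)c(Br)c3)cc2F)ccn1` gives 2670 nM, the highest number of the three: the move a 5.2-fold higher number from compound 1 to compound 3 (0.72 log units; beyond the scatter), and the move a 21-fold higher number from compound 2 to compound 3 (1.31 log units; beyond the scatter).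

Compound 4 `CN(C)CCn1cnnc1-c1cc(Oc2ccc(NC(=O)N/N=C/c3ccc(Cl)cc3Cl)cc2F)ccn1` is not yet measured. It differs from compound 3 in one place: 2,4-dichlorophenyl in place of 3,5-dibromo-4-hydroxyphenyl on a carbon with a double bond to nitrogen.

Within the data shown here, the steps that bear on this change are those into compound 3, since both of them swap an aryl group on the same carbon with a double bond to nitrogen; both raised the number in this assay, by modest and by large amounts. Compound 4 carries a dichlorophenyl, closer to the aryl groups of compound 1 and compound 2 than to that of compound 3. The step is therefore expected to run back down, with an 11-fold lower number from compound 3 to compound 4 (1.03 log units; beyond the scatter). Compound 4 is estimated at 250 nM, with a range from 80 nM to 800 nM.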

Compound 4, half-maximal inhibitory concentration: 390 nM
Beside the measured number, compound 4's estimate is 1.6-fold (0.19 log units) below it; the measured number falls inside the stated range.
By their numbers in this assay, from the lowest: compound 2; then compounds 4 and 1 (each within the scatter of the next); then compound 3.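

In this assay the change to 2,4-dichlorophenyl gives a 6.8-fold lower number from compound 3 to compound 4 (0.84 log units; beyond the scatter) and so shows that a third dichlorophenyl-type aryl group on this carbon with a double bond to nitrogen also stays clear of the high number of compound 3. The new compound also shows that the arrangement of the two chlorines counts at this position: 2,4-dichlorophenyl in place of 2,3-dichlorophenyl gives a 3.0-fold higher number from compound 2 to compound 4 (0.48 log units; beyond the scatter) and lies beyond the scatter. By contrast, chloro in place of fluoro on an aromatic carbon gives a 1.3-fold lower number from compound 1 to compound 4 (0.12 log units; within the scatter) and lies within it.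

No available evidence accounts for these differences. The compounds shown leave open whether a hydroxyphenyl without bromine, or a phenyl carrying an amine or a carboxylic acid, would fall with compound 3 or with compound 2.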